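The compounds below may be only part of what the source reports. "The series", "measured", "known", "first", "only" and "open" are said of these compounds alone.

Of the compounds shown here, two sharing one core have been measured in an assay on blood for inhibition of Polyunsaturated fatty acid 5-lipoxygenase (Homo sapiens); on this read-out lower numbers stand for stronger inhibition and higher numbers for weaker inhibition. Compound 1 `CCC(O)(c1cn(Cc2ccc3c(-c4ccccc4)c(CO)sc3c2)nn1)C(F)(F)F` carries a hydroxymethyl group on its fused five-membered aromatic ring, and in this assay compound 1 gives 64 nM. Compound 2 `CCC(O)(c1cn(Cc2ccc3c(-c4ccccc4)csc3c2)nn1)C(F)(F)F` lacks that group, and in this assay compound 2 gives 598 nM. Among the measured compounds shown here, the one step between them, a 9.3-fold higher number from compound 1 to compound 2 (0.97 log units; beyond the scatter), shows that taking away the hydroxymethyl group weakens inhibition by more than the measurement scatter. For the measured compounds named here, compound 2 thus stands at the highest, weakest, of the two numbers seen so far, with compound 1 as its only neighbour.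

Compound 3 `CCC(O)(c1cn(Cc2ccc3c(-c4ccccc4)c(C(C)O)sc3c2)nn1)C(F)(F)F` has not yet been measured. It differs from compound 2 by a single change: 1-hydroxyethyl in place of hydrogen on an aromatic carbon. Going by the values given here, the hydroxymethyl group of compound 1 and this 1-hydroxyethyl group both bring a hydroxyl-bearing carbon onto that aromatic carbon, so the step from compound 1 to compound 2 is the only comparison that bears on it, and it points to a clear fall in the number once such a group is present. Compound 3 is therefore expected to show a 7.0-fold lower number from compound 2 to compound 3 (0.85 log units; beyond the scatter). The estimate for compound 3 is 85 nM, likely between 25 nM and 300 nM.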

Compound 3, half-maximal inhibitory concentration: 161 nM
For compound 3 the middle estimate is 1.9-fold (0.28 log units) below the measured one, within the range that was stated.
By their numbers in this assay, from the lowest: compound 1; then compound 3; then compound 2.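

In this assay, adding 1-hydroxyethyl on the aromatic carbon next to the ring sulfur gives a 3.7-fold lower number from compound 2 to compound 3 (0.57 log units; beyond the scatter), so the drop in the number seen with hydroxymethyl is no longer a single case: two hydroxyl-bearing groups at this place both give a lower number than hydrogen. The added methyl on the carbon that carries the hydroxyl does not come free, however, as it gives a 2.5-fold higher number from compound 1 to compound 3 (0.40 log units; beyond the scatter), which leaves compound 1 with the lowest number of the three and shows that the size of the gain depends on what that carbon carries. Nothing measured here gives a reason for either step.

As far as these compounds go, it remains open whether the hydroxyl itself matters, which a plain ethyl group or a methoxymethyl group at this place could test by removing the hydroxyl or capping its oxygen. From the compounds shown here alone, it is also open how other groups would compare with these two, such as an aminomethyl group, which puts an amine where the hydroxyl stands, or a longer chain such as 2-hydroxyethyl.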